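A few compounds are considered here, and "the series" means these few. Any claim that something is new, unique, unknown or untested is made for them only; others in the source may bear on it.

Compound 1 `CC(=O)NCC(=O)OCCc1c(-c2ccccc2Cl)c2cc(Cl)ccc2[nH]c1=O` gives 110000 nM
Compound 2 `CC12CCC(C(=O)OCCc3c(-c4ccccc4Cl)c4cc(Cl)ccc4[nH]c3=O)(OC1=O)C2(C)C` gives > 1800000 nM as a limit of the assay
Compound 3 `O=C(CN1C(=O)c2ccccc2C1=O)OCCc1c(-c2ccccc2Cl)c2cc(Cl)ccc2[nH]c1=O` gives 960000 nM

In an ADME assay on HepG2 2.2.15 cells (Homo sapiens) for cytotoxicity (on this read-out lower numbers stand for higher toxicity in this test and higher numbers for lower toxicity in this test), compound 3 holds the higher of the two actual numbers, with an 8.7-fold higher number from compound 1 to compound 3 (0.94 log units; beyond the scatter). The entry for compound 2 is a limit and not a number.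

Compound 4 `O=C(/C=C/c1cccc(C(F)(F)F)c1)OCCc1c(-c2ccccc2Cl)c2cc(Cl)ccc2[nH]c1=O` keeps the shared core but carries 2-(3-(trifluoromethyl)phenyl)ethenyl on the carbonyl carbon. The change is a group of 12 heavy atoms (9 carbon, 3 fluorine; one six-membered aromatic ring of carbon only) in place of a group of 12 heavy atoms (9 carbon, 1 nitrogen, 2 oxygen; one five-membered non-aromatic ring with 1 hetero atom, one six-membered aromatic ring of carbon only), on a carbonyl carbon. The measured steps all involve exchanges in this acyl part. Two are beyond the scatter, an at least 16-fold higher number from compound 1 to compound 2 (1.21 log units; beyond the scatter) and the step to compound 3 already given, while the floor of an at least 1.8-fold lower number from compound 2 to compound 3 (0.27 log units; that floor lies within the scatter) lies within it. Within the data shown here, none of them brings in a group like the one in compound 4, so they show only that such exchanges can matter here. Compound 3 sits high, and compound 1 at 110000 nM shows how far lower this family can fall. A move down is therefore expected, and the estimate is a 3.2-fold lower number from compound 3 to compound 4 (0.51 log units; beyond the scatter). For compound 4 the estimated value is 300000 nM, with an expected range from 60000 nM to 1500000 nM.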

Compound 4, half-maximal cytotoxic concentration: > 1400000 nM
Compound 4: only a limit was reported; the forecaster's own chance of this, stated with the estimate: 20%; middle value at least 4.6-fold (0.66 log units) away from the limit.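

In this assay compound 4 is reported only as a limit: the limit of > 1400000 nM in this assay, at which 1 of the 4 values shown sits. Putting 2-(3-(trifluoromethyl)phenyl)ethenyl in place of acetamidomethyl on the carbonyl carbon gives an at least 12-fold higher number from compound 1 to compound 4 (1.10 log units; beyond the scatter), which shows that a ring-bearing group with no nitrogen or oxygen can also lift the number well clear of compound 1, as the ring-bearing groups containing oxygen did in compound 2 and compound 3. The exchange of the other ring-bearing group gives an at least 1.4-fold higher number from compound 3 to compound 4 (0.16 log units; that floor lies within the scatter), so no order can be set between these two, and the steps between the limits cannot be read.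

Going by these compounds, the actual numbers for compound 2 and compound 4 remain unknown. On these data alone, it also stays open whether an amine, a carboxylic acid or a plain alkyl chain on this carbonyl carbon would give a high or a low number.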